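Free Carboxy in Place of a Second Ester Group

The source may report more compounds than this note shows. Statements on the series, on what has been measured and on what is new or still open speak of the compounds shown alone.

In a physicochemical assay for metabolic stability, read by LC-MS, in phosphate buffer, with a stated time of 3 h, at pH 7.4, tested at 50 uM (a higher number here means that more of the compound is left, a lower number that less of the compound is left), compound 1, whose structure is `CCCCOC(=O)C1=C(S[C@@H]2CN[C@H](C(=O)Nc3cccc(C(=O)OCCCC)c3)C2)[C@H](C)[C@@H]2[C@@H]([C@@H](C)O)C(=O)N12`, gives > 95%, a value that is a limit of the assay rather than a number. Compound 2, with the structure `CC(C)C(=O)OCOC(=O)C1=C(S[C@@H]2CN[C@H](C(=O)Nc3cccc(C(=O)O)c3)C2)[C@H](C)[C@@H]2[C@@H]([C@@H](C)O)C(=O)N12`, likewise gives > 95% in this assay, which is again only a limit. Compound 3, built as `C[C@@H](O)[C@H]1C(=O)N2C(C(=O)OCOC(=O)C(C)(C)C)=C(S[C@@H]3CN[C@H](C(=O)Nc4cccc(C(=O)OCOC(=O)C(C)(C)C)c4)C3)[C@H](C)[C@H]12`, reaches > 95% in this assay, and this too is a limit. Compound 3 therefore stands exactly where the two other measured compounds stand, at the limit of > 95% in this assay, at which 3 of the 3 values shown sit, so nothing on the numbers shown separates it from compound 1 or compound 2, and no step between measured compounds can be computed.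

Compound 4, with the structure `C[C@@H](O)[C@H]1C(=O)N2C(C(=O)OCOC(=O)C(C)(C)C)=C(S[C@@H]3CN[C@H](C(=O)Nc4cccc(C(=O)O)c4)C3)[C@H](C)[C@H]12`, differs from compound 3 in one place: hydrogen in place of (((tert-butyl)carbonyl)oxy)methyl on an oxygen next to a carbonyl group. Compound 2 already carries a free carboxy on the same kind of amide-bearing ring and still sits at the limit with > 95%. On this basis the step from compound 3 to compound 4 is expected to be a step that the limit leaves unreadable from compound 3 to compound 4, nothing beyond the usual scatter. Compound 4 is accordingly estimated at 96%, with a range from 88% to 100%, and will most probably again be reported only as a limit.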

Compound 4, percent of the compound remaining: > 95%
Compound 4 was reported as a limit; the forecaster's own chance of this, stated with the estimate: 80%; the middle value lies beyond the limit too.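

Neither the step from compound 3 to compound 4 nor the step from compound 2 to compound 4 can be read in this assay, because the values are limits and not numbers: the limit of > 95% in this assay, at which 4 of the 4 values shown sit.

The compounds shown leave open whether carboxy in place of ((((tert-butyl)carbonyl)oxy)methoxy)carbonyl changes how much of a compound remains in this assay.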